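Swapping a methyl-bearing ring for a chlorine-bearing one

The source may hold more compounds than are shown below. What is called first, only, known or untested is meant among the compounds shown, and "the series" means these compounds.

Measured in a physicochemical assay for lipophilicity, using the shake flask method; on this read-out higher numbers stand for higher lipophilicity and lower numbers for lower lipophilicity:
- Compound 1 `CC(C)Oc1cc(Oc2ccc(S(C)(=O)=O)cc2)cc(-c2cccc(=O)[nH]2)c1`: 2.82
- Compound 2 `Cc1cc(=O)[nH]c(-c2cc(Oc3ccc(S(C)(=O)=O)cc3)cc(OC(C)C)c2)n1`: 2.43

Of these two, compound 2 has the lower number, 2.43, and compound 1 lies above it by more than the scatter. The next molecule, compound 3 `CC(C)Oc1cc(Oc2ccc(S(C)(=O)=O)cc2)cc(-c2ncc(Cl)c(=O)[nH]2)c1`, changes one group of compound 2: a group of 8 heavy atoms (4 carbon, 2 nitrogen, 1 oxygen, 1 chlorine; one six-membered aromatic ring with 2 hetero atoms) in place of a group of 8 heavy atoms (5 carbon, 2 nitrogen, 1 oxygen; one six-membered aromatic ring with 2 hetero atoms), on an aromatic carbon. The size of the ring and its count of hetero atoms stay the same, while a carbon is exchanged for a chlorine in the count.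

Going by the values given here, only one measured step is available, a number 0.39 log units lower from compound 1 to compound 2 (beyond the scatter). It is a different swap, so it offers only a rough guide to how far a change in this group can move the number. Among the compounds with values here, no measured pair shows the new exchange, which leaves the direction uncertain. A modest upward move is expected in this assay, an estimated a number 0.27 log units higher from compound 2 to compound 3 (within the scatter). Compound 3 is expected at 2.7, within an estimated range of 2.3 to 3.1.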

Compound 3, distribution coefficient: 2.04
Compound 3: middle estimate off by 0.66 log units, on the high side; measured number below the stated range.
By their numbers in this assay, from the lowest: compound 3; then compound 2; then compound 1.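

In this assay, exchanging the methyl-bearing ring for the chlorine-bearing one gives a number 0.39 log units lower from compound 2 to compound 3 (beyond the scatter), so at this position the exchange of carbon for chlorine in the count moves the number down, even though the ring size and its number of hetero atoms stay the same. Measured against the ring with a single hetero atom, the combined change is a number 0.78 log units lower from compound 1 to compound 3 (beyond the scatter), which leaves compound 3 the lowest of the three compounds, each separated from the others by more than the scatter. Nothing available here explains why the chlorine-bearing ring gives the lower number.

With only these three rings, the effect of chlorine cannot be separated from the loss of the methyl group. A fluorine, a bromine, a nitrile or an amine in place of the chlorine could show whether the downward move is particular to chlorine.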